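A few compounds are considered here, and "the series" means these few. Any claim that something is new, unique, unknown or untested is made for them only; others in the source may bear on it.

Values measured so far in a physicochemical assay for lipophilicity, read by mass spectrometry; a lower number here means a more polar compound, a higher number a more lipophilic compound
- Compound 1 `CCc1ccc(NC(=O)C2Cc3cc(OC)c(OC)cc3C2=O)cc1` gives 3.11
- Compound 2 `COc1cc2c(cc1OC)C(=O)C(C(=O)Nc1ccc(Br)cc1)C2` gives 3.03
- Compound 3 `COc1cc2c(cc1OC)C(=O)C(C(=O)Nc1cccc(Br)c1)C2` gives 3.03

In this assay compound 3 reads 3.03 and stands level with compound 2, while compound 1 lies within the scatter of both. The next compound keeps the shared core and changes only the aromatic group. Compound 4 `COc1ccccc1NC(=O)C1Cc2cc(OC)c(OC)cc2C1=O` carries 2-methoxyphenyl in place of 3-bromophenyl on an amide-type nitrogen and has not yet been measured.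

All three measured steps alter that same group. They are a number 0.08 log units lower from compound 1 to compound 2 (within the scatter), a number 0.08 log units lower from compound 1 to compound 3 (within the scatter) and no change at the digits printed from compound 2 to compound 3 (within the scatter), and none goes beyond the scatter. Across these three compounds, then, changing the group has made little measurable difference. None of the steps brings in a methoxy group or a hydrogen-bond acceptor on this group, so they offer only an indirect guide. A small move toward a lower number is expected, perhaps no larger than the scatter, and the range is kept wide. The estimated result is a number 0.23 log units lower from compound 3 to compound 4 (within the scatter) in this assay. The estimate for compound 4 is 2.8, with an expected range from 2.45 to 3.15.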

Compound 4, partition coefficient: 2.08
For compound 4 the middle estimate is 0.72 log units above the measured one, and the stated range ends above it.
By their numbers in this assay, from the lowest: compound 4; then compounds 2, 3 and 1 (each within the scatter of the next).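

In this assay, the aromatic group on the amide-type nitrogen had seemed to matter little, but 2-methoxyphenyl shows that this position can shift the number substantially: the change gives a number 0.95 log units lower from compound 3 to compound 4 (beyond the scatter), and the comparisons with the other two compounds give a number 0.95 log units lower from compound 2 to compound 4 (beyond the scatter) and a number 1.03 log units lower from compound 1 to compound 4 (beyond the scatter). Going by these compounds alone, all three steps lie beyond the scatter, which sets compound 4 apart from three compounds that lie within the scatter of one another, and the entering group has 1 hydrogen-bond acceptor where the groups in compounds 1, 2 and 3 have none of their own to compare in the earlier steps. No independent evidence bears on why the number falls.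

The step from 3-bromophenyl to 2-methoxyphenyl changes both the substituent on the ring and where it sits, so these compounds cannot separate the effect of the methoxy group from the effect of its place on the ring. Also open, as far as these compounds go, is how a ring carrying a hydroxyl group, an amine or a longer ether chain would read in this assay.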